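The source may hold more compounds than are shown below. What is called first, only, known or untested is meant among the compounds shown, and "the series" means these compounds.

Two compounds of the series carry numbers in an assay on membranes from brain with Neuronal acetylcholine receptor; alpha4/beta2 (Rattus norvegicus) as the target; on this read-out higher numbers stand for weaker inhibition and lower numbers for stronger inhibition. Compound 1 `Clc1ncc(OC[C@@H]2CCN2)cc1/C=C/c1ccncc1` gives 0.009 nM in this assay, the highest of the two numbers. Compound 2 `Clc1ncc(OC[C@@H]2CCN2)cc1-c1ccc(Br)nc1` gives 0.0043 nM in this assay, a lower number than that of compound 1 by a margin beyond the scatter. Compound 3 `Fc1cc(/C=C/c2cc(OC[C@@H]3CCN3)cnc2Cl)ccn1` has not been measured in this assay. It departs from compound 1 by a single change: fluoro in place of hydrogen on an aromatic carbon. For the measured compounds named here, no pair of measured compounds shows this change, so its step is not known from the series; a fluoro entering on that aromatic carbon is taken to leave the number about where it is, and the expected step is a 1.1-fold higher number from compound 1 to compound 3 (0.05 log units; within the scatter), no more than the scatter in either direction. Compound 3 is accordingly expected to give 0.01 nM in this assay, with a range from 0.004 nM to 0.025 nM.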

Compound 3, inhibition constant: 0.0031 nM
For compound 3 the middle estimate is 3.2-fold (0.51 log units) above the measured one; measured number outside the range, below it.
By their numbers in this assay, from the lowest: compounds 3 and 2 (each within the scatter of the next); then compound 1.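

In this assay, for the compounds shown here, going from pyridin-4-yl to 2-fluoropyridin-4-yl gives a 2.9-fold lower number from compound 1 to compound 3 (0.46 log units; beyond the scatter), the first step that can be read at this position. The aromatic carbon next to the ring nitrogen therefore takes a fluoro without any loss on this read-out, and this single added heavy atom moves the number beyond the scatter. Nothing at hand explains why the number moves.

On these data alone, whether a chloro, a methyl or an amino group on the same carbon would move the number in the same direction remains open, as does the outcome of a fluoro on the other ring carbons. The compounds shown also leave open whether this step carries over to any other target.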